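The compounds below may be only part of what the source reports. "The series", "measured", "known", "first", "only" and "open" are said of these compounds alone.

Measured so far:
compound 1 `COc1cc(Cl)cc(-c2nn(-c3cccc(NC(=O)Nc4ccc(Cl)c(C(F)(F)F)c4)c3)cc2-c2ccncc2)c1` — 7.28%
compound 2 `COc1cc(Cl)cc(-c2nn(-c3cccc(NC(=O)c4cccc(C(F)(F)F)c4)c3)cc2-c2ccncc2)c1` — 33.2%
compound 3 `O=C(Nc1cccc(-n2cc(-c3ccncc3)c(-c3cc(O)cc(Cl)c3)n2)c1)c1cc(C(F)(F)F)cc(C(F)(F)F)c1` — 30.1%

In a functional assay on HCT-15 cells (Homo sapiens) for inhibition, read by sulforhodamine B assay, with a stated time of 48 h, tested at 10 uM (a lower number here means a stronger effect, a higher number a weaker effect of the compound at the concentration tested), compound 3 stands second highest of the three numbers; its nearest neighbour is compound 2, within the scatter, while compound 1 lies lowest, beyond the scatter. Compound 4 `COc1cc(Cl)cc(-c2nn(-c3cccc(NC(=O)c4cc(C(F)(F)F)cc(C(F)(F)F)c4)c3)cc2-c2ccncc2)c1` differs from compound 3 by methyl in place of hydrogen on an oxygen on an aromatic ring. Within the data shown here, no measured step touches this change: the only measured step, a number 25.9 percentage points higher from compound 1 to compound 2 (beyond the scatter), alters the carbonyl side instead. Compounds 2 and 3, which carry methoxy and hydroxy on the shared core and differ at the carbonyl side as well, give numbers within the scatter of each other, so for compound 4 the expected step of a number 0.1 percentage points lower from compound 3 to compound 4 (within the scatter) stays within the scatter. Compound 4 is therefore estimated at 30%, in the range 15% to 48%.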

Compound 4, a percentage reported as activity, at one concentration (the size of the read-out at that concentration, not a potency): 58.6%
For compound 4 the middle estimate is 28.6 percentage points below the measured one, and the stated range ends below it.
By their numbers in this assay, from the lowest: compound 1; then compounds 3 and 2 (each within the scatter of the next); then compound 4.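

In this assay, the change from hydroxy to methoxy on the 3-chloro-5-hydroxyphenyl group is not neutral when the carbonyl side is held constant, giving a number 28.5 percentage points higher from compound 3 to compound 4 (beyond the scatter). A second single change, trifluoromethyl in place of hydrogen on an aromatic carbon, gives a number 25.4 percentage points higher from compound 2 to compound 4 (beyond the scatter), so each of these changes alone weakens the effect at the concentration tested. Nothing available explains either shift.

The compounds shown leave open whether the free hydroxy itself matters or only the size of the group on that oxygen. An ethoxy group or an amine at this place could help separate the two.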